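One more methoxy on compound 3

A few compounds are considered here, and "the series" means these few. Any claim that something is new, unique, unknown or untested is made for them only; others in the source may bear on it.

Compound 1 `COc1ccc(CNc2ncnc3c2ncn3C2CCCCO2)c(OC)c1OC`: > 37500 nM
Compound 2 `COc1ccc(CNc2ncnc3c2ncn3C2CCCO2)cc1OC`: > 100000 nM
Compound 3 `COc1ccc(CNc2ncnc3c2ncn3C2CCCO2)c(OC)c1`: > 100000 nM

All three compounds were tested in an ADME assay on K562 cells (Homo sapiens) for cytotoxicity, with a stated time of 72 h (on this read-out lower numbers stand for stronger inhibition and higher numbers for weaker inhibition), and none of them yielded a number. Compound 3 stands at > 100000 nM, which is a limit of the assay. Compound 2 sits at the same kind of limit, > 100000 nM. Compound 1 gave > 37500 nM, which is also a limit.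

Compound 4 `COc1ccc(CNc2ncnc3c2ncn3C2CCCO2)c(OC)c1OC` has not yet been measured. It follows from compound 3 through one structural change, methoxy in place of hydrogen on an aromatic carbon, ortho to two methoxy groups. For the measured compounds named here, no measured pair isolates this change, so the expectation rests on limits alone. Compound 4 shares its methoxy pattern on the aromatic ring with compound 1, which gave > 37500 nM, again only a limit. The shared core of these compounds has shown no measurable value in this assay so far, and a further limit is the most likely report. The expected change is none beyond the scatter, with a number no higher from compound 3 to compound 4 (the limit leaves the size open) as the estimated step. For compound 4 the estimate is 100000 nM, with an expected range of 30000 nM to 150000 nM.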

Compound 4, half-maximal inhibitory concentration: > 100000 nM
Compound 4 gave a limit, no number; the forecaster's own chance of this, stated with the estimate: 85%; the middle value lies on the limit itself.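

In this assay compound 4 gives > 100000 nM, which is a limit and not a number. For the compounds shown here, compound 1, compound 2 and compound 3 also stand only as limits, so no step to compound 4 can be read. The compounds shown leave open whether an added methoxy or oxolan-2-yl in place of oxan-2-yl alters the read-out at all.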